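Compound 4: an untested change away from the sulfur

The source may report more compounds than this note shows. Statements on the series, on what has been measured and on what is new or still open speak of the compounds shown alone.

Compound 1 `O=C(/C(=C\c1ccc(Br)cc1)SCc1ccc(Cl)cc1)c1ccc(Br)cc1` gives 1000 nM in a functional assay on DU-145 cells (Homo sapiens) for inhibition, read by trypan blue exclusion, with a stated time of 96 h; on this read-out lower numbers stand for stronger inhibition of growth and higher numbers for weaker inhibition of growth
Compound 2 `O=C(/C(=C\c1ccc(Br)cc1)Sc1ccccc1Br)c1ccc(Br)cc1` gives 1000 nM in this assay
Compound 3 `COc1ccc(S/C(=C/c2ccc(Br)cc2)C(=O)c2ccc(Br)cc2)cc1` gives 20000 nM in this assay

Compound 1 stands level with compound 2, together the lowest of the three numbers, and compound 3 lies well above both. Compound 4 `O=C(/C(=C\c1cc(Cl)cc(Cl)c1Cl)SCc1ccc(Cl)cc1)c1ccc(Br)cc1` differs from compound 1 by 2,3,5-trichlorophenyl in place of 4-bromophenyl on a double-bonded chain carbon bound to a double-bonded chain carbon. The measured steps all concern the group on sulfur. One stayed within the scatter (no change at the digits printed from compound 1 to compound 2 (within the scatter)), while two were large (a 20-fold higher number from compound 1 to compound 3 (1.30 log units; beyond the scatter); a 20-fold higher number from compound 2 to compound 3 (1.30 log units; beyond the scatter)). None of them tests the changed group, so they offer only indirect guidance, and no step beyond the scatter is expected. The estimated step in this assay is no change at the digits printed from compound 1 to compound 4 (within the scatter) (an expectation, with wide uncertainty). The expected value for compound 4 is 1000 nM (estimated range 250 nM to 5000 nM).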

Compound 4, concentration for 50% growth inhibition: 1000 nM
Compound 4: middle estimate and measured number agree at the digits printed; low and high end bracket the measured number.
By their numbers in this assay, from the lowest: compounds 1, 2 and 4 (each within the scatter of the next); then compound 3.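

In this assay, within the data shown here, 2,3,5-trichlorophenyl in place of 4-bromophenyl on a double-bonded chain carbon bound to a double-bonded chain carbon gives no change at the digits printed from compound 1 to compound 4 (within the scatter) and so provides the only direct reading of a change away from the sulfur. This position therefore takes a ring carrying three chlorine atoms instead of one bromine, with 9 heavy atoms instead of 7, without a step beyond the scatter. No measurement shown explains this result. From the compounds shown here alone, whether the position also tolerates an aryl ring bearing an amine or a carboxylic acid remains open.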